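Hydrogen for methyl on the amine of compound 3

The source may hold more compounds than are shown below. What is called first, only, known or untested is meant among the compounds shown, and "the series" means these compounds.

Of the compounds shown here, three with a shared core have been measured in an assay on HEK293 cells for displacement of a labelled ligand from sodium-dependent dopamine transporter (Homo sapiens), tested at 1 uM; a lower number here means less inhibition, a higher number more inhibition at the concentration tested (going by the name of the read-out). Compound 1 `CN(C)C[C@@H]1CCC[C@H]1c1ccc2[nH]cc(C#N)c2c1` gives 50%. Compound 2 `CNC[C@@H]1CCC[C@H]1c1ccc2[nH]cc(C#N)c2c1` gives 49% in this assay. Compound 3 `CN(C)C[C@H]1CCC[C@H]1c1ccc2[nH]cc(C#N)c2c1` gives 56% in this assay, the highest of the three numbers shown, although its gaps to compound 1 and to compound 2 both lie within the scatter.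

Two measured steps are available. a number 1 percentage points lower from compound 1 to compound 2 (within the scatter), hydrogen in place of methyl on an amine nitrogen. a number 6 percentage points higher from compound 1 to compound 3 (within the scatter); the two compounds differ only in configuration as drawn (the fact that compounds 1 and 3 differ only in the configuration as drawn).

Compound 4 `CNC[C@H]1CCC[C@H]1c1ccc2[nH]cc(C#N)c2c1` has not been measured. The change from compound 3 to compound 4 is hydrogen in place of methyl on an amine nitrogen. The same change has been seen once, from compound 1 to compound 2, where the number moved by an amount inside the scatter, so no step beyond the scatter is expected in this assay. The expected step is a number 1 percentage points lower from compound 3 to compound 4 (within the scatter). Compound 4 is therefore estimated at 55%, with a range from 42% to 66%.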

Compound 4, a percentage reported as inhibition, at one concentration (the size of the read-out at that concentration, not a potency): 53%
Compound 4: the middle estimate sits 2 percentage points above what was measured; the range from low to high includes it.
By their numbers in this assay, from the lowest: compounds 2, 1, 4 and 3 (each within the scatter of the next).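

The step from dimethylamino to methylamino now has a second reading, on the other drawn configuration of the saturated ring carbon, and in this assay it is a number 3 percentage points lower from compound 3 to compound 4 (within the scatter). The two readings of this change agree: the same change on two cores in this assay, a number 1 percentage points lower (within the scatter) from compound 1 to compound 2 and a number 3 percentage points lower (within the scatter) from compound 3 to compound 4, 2 percentage points apart, within the scatter of two such steps. The configuration change can now also be read with methylamino in place of dimethylamino, as a number 4 percentage points higher from compound 2 to compound 4 (within the scatter), so on these four compounds neither change moves the number beyond the scatter: the fact that compounds 2 and 4 differ only in the configuration as drawn.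

Since the four compounds are separated by no step beyond the scatter at this single concentration, the amine change and the configuration change remain unresolved as influences on the read-out. Also open, on these data alone, is whether a primary amine, a diethylamino group or a longer chain on the amine nitrogen would give a step beyond the scatter.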